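Moving Fluorines on the Benzyl Group: Compound 3 Expected

The source may report more compounds than this note shows. Statements on the series, on what has been measured and on what is new or still open speak of the compounds shown alone.

Compound 1 `CC1(C)c2[nH]nc(NC(=O)c3ccccc3)c2CN1Cc1ccccc1F`: 450 nM
Compound 2 `CC1(C)c2[nH]nc(NC(=O)c3ccccc3)c2CN1Cc1ccc(F)c(F)c1`: 680 nM

In an assay on Sf21 cells for inhibition of high affinity nerve growth factor receptor (Homo sapiens), read by HTRF, with a stated time of 30 min, in the presence of a further agent that is not named here (on this read-out lower numbers stand for stronger inhibition and higher numbers for weaker inhibition), compound 2 gives 680 nM, which does not stand apart from compound 1 at 450 nM beyond the scatter. Compound 3 `CC1(C)c2[nH]nc(NC(=O)c3ccccc3)c2CN1Cc1c(F)cccc1F` differs from compound 2 by 2,6-difluorophenyl in place of 3,4-difluorophenyl on a saturated chain carbon bound to an amine nitrogen in a ring. Among the compounds with values here, the one measured step, a 1.5-fold higher number from compound 1 to compound 2 (0.18 log units; within the scatter), also shifted fluorine on this same phenyl and stayed within the scatter, so it is the step that bears here. No change beyond the scatter is therefore expected in this assay. Compound 3 is estimated at 500 nM, with a range from 200 nM to 1400 nM. The expected step is a 1.4-fold lower number from compound 2 to compound 3 (0.13 log units; within the scatter).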

Compound 3, half-maximal inhibitory concentration: 520 nM
Estimate against measurement, compound 3: 1.0-fold (0.02 log units) below, within the range that was stated.
By their numbers in this assay, from the lowest: compounds 1, 3 and 2 (each within the scatter of the next).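

In this assay, 2,6-difluorophenyl in place of 3,4-difluorophenyl gives a small step (a 1.3-fold lower number from compound 2 to compound 3 (0.12 log units; within the scatter)), and fluoro in place of hydrogen on an aromatic carbon gives another (a 1.2-fold higher number from compound 1 to compound 3 (0.06 log units; within the scatter)). This position has now carried three fluorinated phenyl groups, and neither rearranging the two fluorines nor adding a second fluoro moves the number beyond the scatter. No measured evidence here explains this. Still open, on these data alone, is whether a methoxy group or an amine on this phenyl, or a longer chain in place of the benzyl carbon, would move the number beyond the scatter.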